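Aryl swap on the shared core: a dichlorothiophene variant

The source may report more compounds than this note shows. Statements on the series, on what has been measured and on what is new or still open speak of the compounds shown alone.

Compound 3 `CC/C(=C(/c1ccc(/C=C/C(=O)O)cc1)c1[nH]c2ccccc2c1Cl)c1ccccc1C(F)(F)F` gives 13 nM in a functional assay on MCF7 cells (Homo sapiens) for antiproliferative activity, read by luminescence and CellTiter-Glo, with a stated time of 5 days (a higher number here means a weaker inhibitor, a lower number a stronger inhibitor), the highest of the three numbers in hand. Compound 1 `CC/C(=C(/c1ccc(/C=C/C(=O)O)cc1)c1[nH]c2ccccc2c1Br)c1ccc(F)cc1Cl` gives 8.53 nM, within the scatter of compound 3, while compound 2 `CC/C(=C(/c1ccc(/C=C/C(=O)O)cc1)c1[nH]c2ccccc2c1Cl)c1ccc(Cl)cc1C#N` gives 0.97 nM. Among the measured compounds shown here, the only one-place step measured is a 13-fold higher number from compound 2 to compound 3 (1.13 log units; beyond the scatter), so the group on this chain carbon moves the number a great deal. Compound 4 `CC/C(=C(/c1ccc(/C=C/C(=O)O)cc1)c1[nH]c2ccccc2c1Cl)c1cc(Cl)sc1Cl` differs from compound 3 by 2,5-dichlorothiophen-3-yl in place of 2-(trifluoromethyl)phenyl on a double-bonded chain carbon bound to a double-bonded chain carbon and a saturated chain carbon. For the measured compounds named here, no measured step covers a thiophene here; the one relevant step, between compound 2 and compound 3, is large, and the entering group carries chlorine as the aryl of compound 2 does. For compound 4 a step down is therefore expected, a 3.7-fold lower number from compound 3 to compound 4 (0.57 log units; beyond the scatter), its size uncertain. Compound 4 is estimated at 3.5 nM, range 0.9 nM to 14 nM.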

Compound 4, half-maximal inhibitory concentration: 20 nM
Compound 4: middle estimate off by 5.7-fold (0.76 log units), on the low side; measured number outside the range, above it.
By their numbers in this assay, from the lowest: compound 2; then compounds 1, 3 and 4 (each within the scatter of the next, the first and the last beyond it).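

The groups 2,5-dichlorothiophen-3-yl and 2-(trifluoromethyl)phenyl read alike on this chain carbon, with a 1.5-fold higher number from compound 3 to compound 4 (0.19 log units; within the scatter) as the step between them. Chlorine on the entering ring does not by itself restore the number of compound 2, since 4-chloro-2-cyanophenyl stands apart with a 21-fold higher number from compound 2 to compound 4 (1.31 log units; beyond the scatter) as its step to the thiophene. No measurement in hand explains this gap.

Whether the nitrile alone accounts for the low number of compound 2 remains open. Also open, as far as these compounds go, is how an amine or a methoxy group on the aryl at this carbon would read.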